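The source may hold more compounds than are shown below. What is called first, only, known or untested is meant among the compounds shown, and "the series" means these compounds.

Compound 1 `CN1C[C@H]2C=C(c3cccnc3)C[C@H](C2)C1` gives 2.1 nM in an in vitro assay on SH-EP1 cells for displacement of a labelled ligand from Neuronal acetylcholine receptor; alpha4/beta2 (Homo sapiens); a lower number here means a stronger inhibitor, a higher number a weaker inhibitor; compound 2 `Fc1ccc(C2=CC3CNCC(C2)C3)cn1` gives 0.4 nM; compound 3 `C1=C(c2cccnc2)C[C@H]2CNC[C@@H]1C2` gives 0.2 nM.

Compound 4 `CN1CC2C=C(c3ccc(F)nc3)CC(C2)C1` has not yet been measured in this assay. It differs from compound 2 by methyl in place of hydrogen on an amine nitrogen in a ring. The same change, (methyl in place of hydrogen on an amine nitrogen in a ring), separates compound 3 from compound 1, where the step was an 11-fold higher number from compound 3 to compound 1 (1.02 log units; beyond the scatter). The difference between the cores of compound 2 and compound 3 is not broken down here, and the two values lie within the usual scatter of each other. Since the change in the place it occupies is the same in both pairs, compound 4 is expected to show a step of about an 11-fold higher number from compound 2 to compound 4 (1.05 log units; beyond the scatter) from compound 2, resting on the step from compound 3 to compound 1. Compound 4 is therefore estimated at 4.5 nM, with a range from 1.5 nM to 13 nM.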

Compound 4, inhibition constant: 18 nM
For compound 4 the middle estimate is 4.0-fold (0.60 log units) below the measured one, outside the stated range (above it).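

In this assay, methyl in place of hydrogen on an amine nitrogen in a ring again gives a higher number, with a 45-fold higher number from compound 2 to compound 4 (1.65 log units; beyond the scatter) on this core, so the direction of the change carries over between the two cores shown. The size of the step does not carry over: the same change on two cores in this assay, an 11-fold higher number (1.02 log units; beyond the scatter) from compound 3 to compound 1 and a 45-fold higher number (1.65 log units; beyond the scatter) from compound 2 to compound 4, 4.3-fold (0.63 log units) apart, beyond the scatter of two such steps. These two pairs do not show which difference between the cores goes with the larger step, nor how large the step would be on any further core.

The compounds shown leave open whether ethyl or a longer chain on that nitrogen would give a step like that of methyl. They also leave open how the step would run with chlorine or a methoxy group in place of the fluorine of compound 2.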